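A few compounds are considered here, and "the series" means these few. Any claim that something is new, unique, unknown or untested is made for them only; others in the source may bear on it.

Measured so far, in a functional assay on the whole organism (Tail, strain ICR) with Mus musculus as the target, in the tail flick test, with a stated time of 90 min, at a dose of 25 umol/kg by the oral route; on this read-out lower numbers stand for a weaker effect and higher numbers for a stronger effect at the one dose given:

compound 1, `NC(=O)C[C@H](NC(=O)CN(c1ncnc2c1ncn2C1CCCCO1)C1CC1)C(=O)OCc1ccccc1`, gives 35%
compound 2, `CC(C)C[C@H](NC(=O)CN(c1nc(Cl)nc2[nH]cnc12)C1CC1)C(=O)OCc1ccccc1`, gives 15.2%
compound 3, `CC(C)C[C@H](NC(=O)CN(c1ncnc2c1ncn2C1CCCCO1)C1CC1)C(=O)OCc1ccccc1`, gives 28.2%

Compound 1 and compound 3 share a core and differ only by carbamoyl in place of isopropyl on a saturated chain carbon, two bonds along the chain from an amide-type nitrogen and a carbonyl carbon. The step this change made, measured in this assay, was a number 6.8 percentage points higher from compound 3 to compound 1 (within the scatter).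

Compound 4, `NC(=O)C[C@H](NC(=O)CN(c1nc(Cl)nc2[nH]cnc12)C1CC1)C(=O)OCc1ccccc1`, has not yet been measured. It stands to compound 2 as compound 1 stands to compound 3: the change is carbamoyl in place of isopropyl on a saturated chain carbon, two bonds along the chain from an amide-type nitrogen and a carbonyl carbon, and the place described is the same word for word, so it is the same change on a different core. How the core of compound 2 differs from the core of compound 3 is not broken down here.

For the measured compounds named here, since the one measured example of this change gave a number 6.8 percentage points higher from compound 3 to compound 1 (within the scatter), a step of about the same size is expected from compound 2 to compound 4, namely a number 6.8 percentage points higher from compound 2 to compound 4 (within the scatter). Compound 4 is therefore estimated at 22% in this assay, most likely between 10% and 34%.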

Compound 4, a percentage reported as activity, at one dose (the size of the read-out at that dose, not a potency): 32.3%
For compound 4 the middle estimate is 10.3 percentage points below the measured one, within the range that was stated.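

In this assay, putting carbamoyl in place of isopropyl on the second core gave a number 17.1 percentage points higher from compound 2 to compound 4 (beyond the scatter). Set beside the step on the first core, the two steps do not differ by more than repeated measurements would be expected to: the same change on two cores in this assay, a number 6.8 percentage points higher (within the scatter) from compound 3 to compound 1 and a number 17.1 percentage points higher (beyond the scatter) from compound 2 to compound 4, 10.3 percentage points apart, within the scatter of two such steps This suggests that the change can be carried between these two cores, but it rests on only two pairs, and one of those steps lies within the scatter, so it does not establish that the step is equal on both cores or that it would hold on any other core.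

The compounds shown carry only isopropyl or carbamoyl at this place. On these data alone, what an amine, a carboxylic acid or a longer chain would give there remains open.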